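The source may hold more compounds than are shown below. What is called first, only, known or untested is meant among the compounds shown, and "the series" means these compounds.

Measured compounds:
- compound 1 `COc1cc(-c2nn(-c3cccc(NC(=O)Nc4ccc(Cl)c(Cl)c4)c3)cc2-c2ccncc2)ccc1Cl`: 151 nM
- compound 2 `O=C(Nc1cccc(-n2cc(-c3ccncc3)c(-c3ccc(Cl)c(O)c3)n2)c1)Nc1ccc(Cl)c(Cl)c1`: 679 nM

In a functional assay on HOP-92 cells (Homo sapiens) for inhibition, read by sulforhodamine B assay, with a stated time of 48 h (a higher number here means a weaker inhibitor of growth, a lower number a stronger inhibitor of growth), compound 1 gives 151 nM and stands lowest of the two numbers; compound 2 gives 679 nM, and the step from compound 1 to compound 2 is a 4.5-fold higher number from compound 1 to compound 2 (0.65 log units; beyond the scatter), made by a hydrogen in place of methyl on an oxygen on an aromatic ring.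

Compound 3 `COc1cc(-c2nn(-c3cccc(NC(=O)Nc4ccc(Cl)c(C(F)(F)F)c4)c3)cc2-c2ccncc2)ccc1Cl` is not yet measured. It differs from compound 1 by trifluoromethyl in place of chloro on an aromatic carbon, ortho to a chloro group and meta to a large group, so that the 3,4-dichlorophenyl becomes 4-chloro-3-(trifluoromethyl)phenyl. For the measured compounds named here, the one measured step, from compound 1 to compound 2, sits on the other end of the shared core and says nothing about this position. Going by the values given here, no measured step bears on the change from compound 1 to compound 3, so the expectation rests on compound 1 alone, with a wide range and no step beyond the scatter in either direction. The estimated step from compound 1 to compound 3 is a 1.2-fold lower number from compound 1 to compound 3 (0.07 log units; within the scatter) in this assay. Compound 3 is therefore expected at about 130 nM, within 40 nM to 450 nM.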

Compound 3, concentration for 50% growth inhibition: 499 nM
Estimate against measurement, compound 3: 3.8-fold (0.58 log units) below; the whole stated range lies below it.
By their numbers in this assay, from the lowest: compound 1; then compounds 3 and 2 (each within the scatter of the next).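

Working from this assay, the aromatic carbon ortho to a chloro group on the 3,4-dichlorophenyl end proves sensitive to substitution: trifluoromethyl in place of chloro gives a 3.3-fold higher number from compound 1 to compound 3 (0.52 log units; beyond the scatter), so chloro is the better of the two groups here. For the compounds shown here, the only step available earlier, a 4.5-fold higher number from compound 1 to compound 2 (0.65 log units; beyond the scatter), lay at the other end of the molecule, so this is the first reading at this end, and it shows that both ends of the shared core can move the number beyond the scatter. No measurement in hand bears on what lies behind this step at the 3,4-dichlorophenyl end.

Only chloro and trifluoromethyl are shown at this carbon, so it remains open whether a smaller group such as hydrogen or methyl, or a nitrile, would keep the number of compound 1 or raise it further. Also open is whether the same replacement would give a step of similar size with the hydroxyl of compound 2 in place of the methoxy of compound 1, since the two changes are shown only separately.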